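Swapping Chloro for Methoxy on the Unsaturated Chain

A few compounds are considered here, and "the series" means these few. Any claim that something is new, unique, unknown or untested is made for them only; others in the source may bear on it.

Compound 1 `COc1cccc(CCCC(=O)Nc2nc3ccccc3c(=O)s2)c1`: 389 nM
Compound 2 `O=C(C/C=C/c1cccc(Cl)c1)Nc1nc2ccccc2c(=O)s1`: > 1000 nM
Compound 3 `O=C(CCCc1cccc(Cl)c1)Nc1nc2ccccc2c(=O)s1`: > 1000 nM

Of the compounds shown here, three sharing one core have been measured in an in vitro assay on cells for inhibition of Amine oxidase [flavin-containing] B (Homo sapiens), read by fluorescence and Amplex Red, with stated times of 30 min and 45 min; a lower number here means a stronger inhibitor, a higher number a weaker inhibitor. Compound 1 gives 389 nM. Compound 2 reaches only > 1000 nM, which is a limit of the assay and not a number. Compound 3 likewise stops at > 1000 nM, again a limit. Compound 2 therefore stands at the weak end of what has been seen so far, with no exact number of its own.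

The unmeasured compound 4 `COc1cccc(/C=C/CC(=O)Nc2nc3ccccc3c(=O)s2)c1` differs from compound 2 in one place: methoxy in place of chloro on an aromatic carbon. Among the compounds with values here, the one measured step that bears on this change runs in the opposite direction: an at least 2.5-fold higher number from compound 1 to compound 3 (0.41 log units; beyond the scatter). Read backwards, putting methoxy in the place of chloro should make the number lower, that is, the inhibition stronger, by a size that is at least modest but not pinned down, since the value of compound 3 is a limit (the limit of > 1000 nM in this assay, at which 2 of the 3 values shown sit). Compound 1 shows what a methoxy-bearing member of this series can reach, and compound 4 may land near it. Compound 4 is therefore expected to give about 500 nM in this assay, most likely between 150 nM and 2000 nM. That expected change amounts to an at least 2.0-fold lower number from compound 2 to compound 4 (0.30 log units; that floor lies within the scatter).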

Compound 4, half-maximal inhibitory concentration: 238 nM
Compound 4: middle estimate off by 2.1-fold (0.32 log units), on the high side, within the range that was stated.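

The change from chloro to methoxy on this aromatic carbon can now be read in a second pair of compounds that differ in that one place only, and in this assay it gives an at least 4.2-fold lower number from compound 2 to compound 4 (0.62 log units; beyond the scatter). Compound 2 stands at > 1000 nM, which is a limit of the assay and not a number, so this step has a floor but no exact size. The earlier compounds offered this change once, whereas compound 4 shows the same direction in a second pair, with methoxy the stronger of the two groups in both, though the sizes of the two steps cannot be compared: the same change on two cores in this assay, an at least 2.5-fold higher number (0.41 log units; beyond the scatter) from compound 1 to compound 3 and an at least 4.2-fold higher number (0.62 log units; beyond the scatter) from compound 4 to compound 2; the limit leaves it open whether they differ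

Still open, from the compounds shown here alone, is how much stronger methoxy really is than chloro in either pair, and whether the result depends on methoxy itself, a question that a hydroxyl, an amine or an ethoxy on the same aromatic carbon of the 3-methoxyphenyl group would address. Also open, going by these compounds, is whether the same change holds with a longer chain or with the group placed elsewhere on the six-membered aromatic ring.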